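The source may report more compounds than this note shows. Statements on the series, on what has been measured and on what is new or still open speak of the compounds shown alone.

Measured so far:
compound 1, `Cc1c(Oc2ccc(F)cc2OCCn2ccc(=O)[nH]c2=O)cc(F)c2ccc(C#N)cc12`
compound 2, `Cc1cc(Oc2ccc(F)cc2OCCn2ccc(=O)[nH]c2=O)c(F)c2cc(C#N)ccc12`
compound 3, `Cc1c(Oc2ccc(F)cc2OCCn2ccc(=O)[nH]c2=O)cc(Cl)c2ccc(C#N)cc12`

In a toxicity assay on MT2 cells (Homo sapiens) for cytotoxicity, read by MTT assay (a higher number here means that more compound is tolerated, a lower number that less compound is tolerated), compound 1 reaches only a limit of the assay, > 100000 nM. Compound 2 gives 45000 nM in this assay. Compound 3 gives 82000 nM in this assay. Compound 2 and compound 3 lie within the scatter of each other, so no order between them can be read. Compound 1 sits at the limit (the limit of > 100000 nM in this assay, at which 1 of the 3 values shown sits).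

For the measured compounds named here, the one measured step on the same position is an at least 1.2-fold lower number from compound 1 to compound 3 (0.08 log units; that floor lies within the scatter), and since compound 1 is a limit it is a floor that itself falls within the scatter.

Compound 4, `Cc1cc(Oc2ccc(F)cc2OCCn2ccc(=O)[nH]c2=O)c(C)c2cc(C#N)ccc12`, differs from compound 3 by methyl in place of chloro on an aromatic carbon. Going by the values given here, no measured step covers a methyl at this place; the only step at this position is the halogen exchange from compound 1 to compound 3, which stays within the scatter. The change is therefore expected to shift this assay little, with the estimated step of a 1.2-fold lower number from compound 3 to compound 4 (0.07 log units; within the scatter) lying within the scatter in either direction.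

Compound 4 is expected to give about 70000 nM in this assay, with a range from 30000 nM to 150000 nM.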

Compound 4, half-maximal cytotoxic concentration: > 100000 nM
Compound 4: only a limit was reported (the forecaster's own chance of this, stated with the estimate: 30%); at least 1.4-fold (0.15 log units) between middle value and limit.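

At this position, on an aromatic carbon para to a methyl group, methyl in place of fluoro gives a step beyond the scatter in this assay, an at least 2.2-fold higher number from compound 2 to compound 4 (0.34 log units; beyond the scatter), the first in the series to pass it. Methyl in place of chloro gives an at least 1.2-fold higher number from compound 3 to compound 4 (0.08 log units; that floor lies within the scatter), so no order between chloro and methyl can be read here. Compound 1 and compound 4 both stand only as limits of the assay, so the step between them cannot be read: the limit of > 100000 nM in this assay, at which 2 of the 4 values shown sit.

On these data alone, how an amine, a methoxy group or a longer chain such as ethyl would read at this place in this assay remains open. As far as these compounds go, the actual value of compound 4 also remains open, so the full size of each step to it is unknown.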